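Methoxy in place of methyl: compound 2 to compound 4

The source may report more compounds than this note shows. Statements on the series, on what has been measured and on what is new or still open speak of the compounds shown alone.

Measured so far in a functional assay on the whole organism for inhibition, with Rattus norvegicus as the target; a lower number here means that less compound is needed, a higher number that more compound is needed for the effect:
- Compound 1 `COc1cccc(N2CCN(CCCCN3C(=O)SC4(CCCC4)C3=O)CC2)n1` gives > 100 mg/kg, a limit.
- Compound 2 `Cc1cccnc1N1CCN(CCCCN2C(=O)SC3(CCCC3)C2=O)CC1` gives > 50 mg/kg, a limit.
- Compound 3 `N#Cc1cccnc1N1CCN(CCCCN2C(=O)CSC2=O)CC1` gives > 100 mg/kg, a limit.

None of the three compounds has yet given a number in this assay. The values gather at the limit of > 100 mg/kg in this assay, at which 2 of the 3 values shown sit, and at the limit of > 50 mg/kg in this assay, at which 1 of the 3 values shown sits. From the compounds shown here alone, compound 2 therefore stands only as a limit, > 50 mg/kg, and its true position is unknown.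

Compound 4 `COc1cccnc1N1CCN(CCCCN2C(=O)SC3(CCCC3)C2=O)CC1` keeps the core of compound 2 and carries methoxy in place of methyl on an aromatic carbon. The change is 3-methylpyridin-2-yl to 3-methoxypyridin-2-yl.

For the measured compounds named here, only one measured step bears on this change, and that is a step that the two limits leave unreadable from compound 1 to compound 2. It offers no size to carry over and no direction. Nothing measured points to a step beyond the scatter, so none is expected, and the estimated shift is read as a step that the limit leaves unreadable from compound 2 to compound 4. Another limit is the likeliest report for compound 4 in this assay. For compound 4 the estimated value is 80 mg/kg, with an expected range from 25 mg/kg to 200 mg/kg.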

Compound 4, dose for half-maximal effect: < 57 mg/kg
Compound 4: a limit, no number; the forecaster's own chance of this, stated with the estimate: 75%; middle value at least 1.4-fold (0.14 log units) from the limit.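

In this assay, for the compounds shown here, compound 4 gives < 57 mg/kg, a limit and not a number, and it is the first limit whose sign opens toward less compound. The exchange of 6-methoxypyridin-2-yl for 3-methoxypyridin-2-yl on an amine nitrogen in a ring gives an at least 1.7-fold lower number from compound 1 to compound 4 (0.24 log units; that floor lies within the scatter), so the place of the methoxy on the ring now has a direction, though not yet a size that can be trusted beyond that floor. The steps between compound 1 and compound 2 and between compound 2 and compound 4 cannot be read, so methoxy in place of methyl on this aromatic carbon still has neither a size nor a firm direction.

From the compounds shown here alone, the true position of compound 4 in this assay stays open, and with it whether the 3-methoxypyridin-2-yl group really sets compound 4 apart from the 3-methylpyridin-2-yl group of compound 2. Also open, going by these compounds, is how an ethoxy group or a chlorine atom on the same aromatic carbon would read on the core of compound 4.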